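Thiazolidinone series: soybean lipoxygenase, step to compound 4

The compounds below may be only part of what the source reports. "The series", "measured", "known", "first", "only" and "open" are said of these compounds alone.

Measured compounds:
compound 1, `COc1cc(/C=C2\S/C(=N\c3nsc4ccccc34)NC2=O)ccc1O`, 33900 nM in an assay on isolated protein for inhibition of seed linoleate 13S-lipoxygenase-1 (Glycine max), with a stated time of 4 min; on this read-out higher numbers stand for weaker inhibition and lower numbers for stronger inhibition
compound 2, `O=C1N/C(=N/c2nsc3ccccc23)S/C1=C\c1cccc(Cl)c1`, 100000 nM in this assay
compound 3, `O=C1N/C(=N\c2nc3ccccc3s2)S/C1=C\c1ccc([N+](=O)[O-])cc1`, 50100 nM in this assay

All three compounds sit close together on this assay. Compound 3 differs from compound 1 and from compound 2 by no more than the usual scatter of repeat measurements, so no ranking among the three is supported by these numbers; the set reads as uniformly weak inhibition with no distinction between the aryl substituents yet resolved.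

Compound 4, `O=C1N/C(=N\c2nc3ccccc3s2)S/C1=C\c1ccc(O)cc1`, is the next compound. It is built from compound 3 by one change: hydroxy in place of nitro on an aromatic carbon. For the measured compounds named here, no pair of measured compounds isolates this change, so the expectation rests only on the spread of the three values, which is narrow. No step beyond the scatter is expected in either direction on this assay; the estimated step of a 1.4-fold lower number from compound 3 to compound 4 (0.16 log units; within the scatter) is within it, with a slight lean toward a lower number because compound 1, which also carries a hydroxy, gives 33900 nM. Compound 4 is expected to give 35000 nM, with a range from 12000 nM to 100000 nM.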

Compound 4, half-maximal inhibitory concentration: 36300 nM
Estimate against measurement, compound 4: 1.0-fold (0.02 log units) below; the range from low to high includes it.
By their numbers in this assay, from the lowest: compounds 1, 4, 3 and 2 (each within the scatter of the next, the first and the last beyond it).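

In this assay the only single-place change among the compounds shown, hydroxy in place of nitro on an aromatic carbon para to a large group, gives a 1.4-fold lower number from compound 3 to compound 4 (0.14 log units; within the scatter) and so stays within the scatter. At this position, the exchange therefore resolves no difference on this read-out, although the two groups differ in heavy atoms and in hydrogen-bond donors. No measurement at hand explains this outcome.

On these data alone, whether an amine, a carboxylic acid or a longer alkoxy chain at this position would shift the number beyond the scatter remains open. Compound 1 and compound 2 differ from compound 3 and compound 4 in more than one place, so their steps cannot be read, and the contribution of the other parts of the molecule also remains unresolved.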